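The source may hold more compounds than are shown below. What is called first, only, known or untested is meant among the compounds shown, and "the series" means these compounds.

Compound 1 `O=c1cc(CSc2nc3ccccc3s2)oc2ccc(Cl)cc12` was tested in a functional assay on LM7 cells (Homo sapiens) for cytotoxicity, read by MTT assay, with a stated time of 72 h; on this read-out higher numbers stand for weaker inhibition and lower numbers for stronger inhibition. In this assay compound 1 gives only a limit, > 25000 nM, not a number. Compound 2 `Cc1cc(C)n2nc(SCc3nnc(SCc4cc(=O)c5ccccc5o4)o3)nc2n1` likewise returns a limit in this assay, > 25000 nM. Compound 3 `Cc1cc(O)cc2oc(=O)cc(CSc3nc4ccccc4s3)c12` also gives only a limit in this assay, > 25000 nM. Compound 1 therefore stands where every measured compound stands: at the limit of > 25000 nM in this assay, at which 3 of the 3 values shown sit. Compound 4 `Cc1ccc2oc(CSc3nc4ccccc4s3)cc(=O)c2c1` has not yet been measured in this assay; it differs from compound 1 by methyl in place of chloro on an aromatic carbon. With three limits and no numbered step to lean on, the expected step is a step that the limit leaves unreadable from compound 1 to compound 4, meaning no shift beyond the scatter. Compound 4 is thus estimated at 30000 nM in this assay, within 10000 nM to 100000 nM, most likely again reported as a limit.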

Compound 4, half-maximal inhibitory concentration: > 25000 nM
Compound 4 gave a limit, no number; the forecaster's own chance of this, stated with the estimate: 85%; the middle value lies beyond the limit too.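

Compound 1 and compound 4 both return only a limit, not a number, and the step between them, methyl in place of chloro, cannot be read. The compounds shown leave open how these two groups actually compare in this assay, and what kind of structure would give a measurable number there.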